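A few compounds are considered here, and "the series" means these few. Any claim that something is new, unique, unknown or untested is made for them only; others in the source may bear on it.

Measured in a functional assay on DU-145 cells (Homo sapiens) for inhibition, read by trypan blue exclusion, with a stated time of 96 h; on this read-out higher numbers stand for weaker inhibition of growth and lower numbers for stronger inhibition of growth:
- compound 1 `O=C(O)c1ccc(C(=O)/C(=C\c2ccc(F)c([N+](=O)[O-])c2)SCc2ccc(C(F)(F)F)cc2)cc1`: 1000 nM
- compound 2 `O=C(O)c1ccc(C(=O)/C(=C\c2ccc(Cl)c([N+](=O)[O-])c2)SCc2ccc(C(F)(F)F)cc2)cc1`: 1000 nM
- compound 3 `Cc1ccc(CS(=O)(=O)/C(=C/c2ccccc2Br)C(=O)c2ccc(Cl)cc2)cc1`: 25000 nM

Compound 2 stands level with compound 1, and together they hold the lowest of the three numbers. Compound 3 sits well apart at 25000 nM.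

Compound 4 `Cc1ccc(CS/C(=C/c2ccc(Cl)c([N+](=O)[O-])c2)C(=O)c2ccc(C(=O)O)cc2)cc1` follows from compound 2 by one change: methyl in place of trifluoromethyl on an aromatic carbon, para to a large group.

Going by the values given here, the only measured single-place step is no change at the digits printed from compound 1 to compound 2 (within the scatter), and it concerns chloro and fluoro, not this group. Among the compounds with values here, no measured step tests the trifluoromethyl group, and compound 3 differs from compound 2 in several places, so it gives no size for this change. The data therefore offer no basis for a direction, and no shift beyond the scatter is expected in this assay, though the range is kept wide. The expected step is no change at the digits printed from compound 2 to compound 4 (within the scatter). The estimated value for compound 4 is 1000 nM, with an expected range from 350 nM to 3500 nM.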

Compound 4, concentration for 50% growth inhibition: 1000 nM
Compound 4: middle estimate and measured number agree at the digits printed; measured number inside the range.
By their numbers in this assay, from the lowest: compounds 1, 2 and 4 (each within the scatter of the next); then compound 3.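

In this assay, methyl in place of trifluoromethyl, read as 4-(trifluoromethyl)benzyl to 4-methylbenzyl, gives no change at the digits printed from compound 2 to compound 4 (within the scatter). This is the first single-place reading at this position, as the earlier step concerned only chloro and fluoro, so the number in this series is shown not to depend on trifluoromethyl here: with chloro in the core, a group of four heavy atoms gives way to one of a single heavy atom and the read-out stays level. No measurement on hand accounts for this flat step.

Still open, going by these compounds, is whether a different group at this carbon, such as an amine, a carboxylic acid or a longer chain, would hold the number. Also open, on these data alone, is whether the same exchange would read alike with fluoro in place of chloro.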